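The source may hold more compounds than are shown below. What is called first, only, known or untested is meant among the compounds shown, and "the series" means these compounds.

In a functional assay on HUVEC cells (Homo sapiens) for antiproliferative activity, read by sulforhodamine B assay, with a stated time of 48 h (a lower number here means a stronger inhibitor, a higher number a weaker inhibitor), compound 1 (`COc1cc2c(Nc3ccc(NC(=O)Nc4cccc(F)c4)c(F)c3)ncnc2cc1OCC1CCN(C)CC1`) gives 185 nM. Its nearest neighbour is compound 2 (`COc1cc2c(Nc3ccc(NC(=O)Nc4cccc(F)c4)cc3)ncnc2cc1OCC1CCN(C)CC1`) at 179 nM, and the furthest is compound 3 (`CN1CCC(COc2ccc3c(Nc4ccc(NC(=O)NC5CC5)cc4)ncnc3c2)CC1`) at 324 nM, still within the scatter of compound 1. Compound 4 (`CN1CCC(COc2ccc3c(Nc4ccc(NC(=O)Nc5cccc(F)c5)c(F)c4)ncnc3c2)CC1`) differs from compound 1 by hydrogen in place of methoxy on an aromatic carbon, with hydrogen in place of methoxy on an aromatic carbon. Among the measured compounds shown here, no measured step makes this exact change. For the measured compounds named here, the one measured step, a 1.0-fold lower number from compound 1 to compound 2 (0.01 log units; within the scatter), involves a different swap, so it offers only weak guidance. Compound 3 also has no methoxy there, but it differs in other ways too, and its 324 nM suggests only a modest move towards a higher number. The expected change is a 1.4-fold higher number from compound 1 to compound 4 (0.13 log units; within the scatter), which is no shift beyond the scatter. For compound 4, the estimate is 250 nM, with an expected range of 100 nM to 650 nM.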

Compound 4, half-maximal inhibitory concentration: 67 nM
For compound 4 the middle estimate is 3.7-fold (0.57 log units) above the measured one, outside the stated range (below it).
By their numbers in this assay, from the lowest: compound 4; then compounds 2, 1 and 3 (each within the scatter of the next).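

In this assay, replacing the methoxy ortho to the (1-methylpiperidin-4-yl)methoxy group with hydrogen gives a 2.8-fold lower number from compound 1 to compound 4 (0.44 log units; beyond the scatter). This is the first single change shown that moves the number beyond the scatter, and it shows that this methoxy is not needed for activity here. No evidence is available to explain the gain. Open, as far as these compounds go, is how other groups on this carbon, such as ethoxy, chloro or an amine, would compare with hydrogen. Also open, from the compounds shown here alone, is whether the gain would hold in compounds with a different urea substituent.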